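The source may hold more compounds than are shown below. What is called first, only, known or untested is meant among the compounds shown, and "the series" means these compounds.

Measured compounds in an ADME assay on MDCKII-LE cells (Canis lupus familiaris) for permeability; a higher number here means that the compound crosses the layer faster, a lower number that the compound crosses the layer more slowly:
- compound 1 `Cc1cnc(NC(=O)c2cc(Oc3ccc(C(=O)N(C)C)cc3)c3cn(C)nc3c2)cn1`: 14.6 10^-6 cm/s
- compound 2 `Cc1cnc(NC(=O)c2cc(Oc3ccc(S(C)(=O)=O)cc3)c3cn(C)nc3c2)cn1`: 20.4 10^-6 cm/s
- compound 3 `CNS(=O)(=O)c1ccc(Oc2cc(C(=O)Nc3cnc(C)cn3)cc3nn(C)cc23)cc1`: "not determined" (no result reported)

Going by the values given here, compound 2 holds the higher of the two numbers in this assay, but its only measured neighbour, compound 1, differs by a 1.4-fold higher number from compound 1 to compound 2 (0.15 log units; within the scatter), so the two stand together within the scatter. Compound 3 adds nothing numerical.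

Compound 4 `Cc1cnc(NC(=O)c2cc(Oc3ccc(S(C)(=O)=O)cc3)c3cn(CCO)nc3c2)cn1` is to be measured. It differs from compound 2 by hydroxymethyl in place of hydrogen on a saturated chain carbon bound to an aromatic nitrogen.

Among the compounds with values here, no measured step covers this kind of change. Within the data shown here, the one step, a 1.4-fold higher number from compound 1 to compound 2 (0.15 log units; within the scatter), swaps one group for another on an aromatic carbon and stays within the scatter; it says nothing about adding a hydroxymethyl to a saturated chain carbon bound to an aromatic nitrogen. The expectation for compound 4 therefore rests on the narrow spread of the two measured numbers and on the small size of the change counted, and is for a number not far from compound 2, if anything somewhat lower: the step from compound 2 to compound 4 is estimated at a 1.9-fold lower number from compound 2 to compound 4 (0.27 log units; within the scatter).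

Compound 4 is expected to give about 11 10^-6 cm/s in this assay, with a range from 5 10^-6 cm/s to 22 10^-6 cm/s.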

Compound 4, apparent permeability: 6.3 10^-6 cm/s
Estimate against measurement, compound 4: 1.7-fold (0.24 log units) above, within the range that was stated.
By their numbers in this assay, from the lowest: compound 4; then compounds 1 and 2 (each within the scatter of the next).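

In this assay, methyl to 2-hydroxyethyl on the aromatic nitrogen, which places a hydroxymethyl on a saturated chain carbon bound to that nitrogen, gives a 3.2-fold lower number from compound 2 to compound 4 (0.51 log units; beyond the scatter). This is the first step in the series to lie beyond the scatter, whereas the swap on an aromatic carbon, a 1.4-fold higher number from compound 1 to compound 2 (0.15 log units; within the scatter), stayed within it, so this position is shown to be one where a change can register in this read-out, though only a single pair supports that. Nothing available explains the step.

An ethyl or a 2-methoxyethyl at the same place would help separate the contribution of the added chain from that of the terminal hydroxyl, and a longer chain or an amine would show whether the step continues in the same direction. Also open, from the compounds shown here alone, is whether the step carries over to the dimethylcarbamoyl of compound 1 in place of the methylsulfonyl of compound 2.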